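A few compounds are considered here, and "the series" means these few. Any claim that something is new, unique, unknown or untested is made for them only; others in the source may bear on it.

Working notes on the series.

Two compounds have numbers in a functional assay on A549 cells (Homo sapiens) for inhibition, read by sulforhodamine B assay, with a stated time of 48 h; on this read-out higher numbers stand for weaker inhibition of growth and lower numbers for stronger inhibition of growth. Compound 1 `Cc1c(C[C@]2(C)C3=CCC[C@](C)(C(=O)O)[C@H]3CC[C@H]2C)c2cc(Cl)ccc2n1C(c1ccccc1)c1ccccc1` in this assay gives 9100 nM. Compound 2 `COC(=O)[C@@]1(C)CC[C@@H]2C3=C1CC[C@@H](C)[C@]3(C)Cc1c2[nH]c2ccccc12` in this assay gives 4600 nM. The two values sit within the usual scatter of each other, so no order between compound 1 and compound 2 can be claimed from these numbers; compound 2 merely stands at one end of a pair that does not separate.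

Compound 3 `COC(=O)[C@@]1(C)CC[C@@H]2C3=C1CC[C@@H](C)[C@]3(C)Cc1c2[nH]c2ccc(Br)cc12` is not yet measured. Relative to compound 2 the change is bromo in place of hydrogen on an aromatic carbon. Among the compounds with values here, no measured pair in this set shows what such a change does, so the expected step is small and its direction is open: the estimated step from compound 2 to compound 3 is a 1.3-fold lower number from compound 2 to compound 3 (0.12 log units; within the scatter), a step not expected to exceed the scatter. On that basis compound 3 is expected to give about 3500 nM in this assay, with a range from 1200 nM to 10000 nM.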

Compound 3, concentration for 50% growth inhibition: 17000 nM
Compound 3: the middle estimate sits 4.9-fold (0.69 log units) below what was measured, outside the stated range (above it).
By their numbers in this assay, from the lowest: compounds 2, 1 and 3 (each within the scatter of the next, the first and the last beyond it).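

In this assay bromo in place of hydrogen on this aromatic carbon, meta to a fused ring and para to a fused ring, gives a 3.7-fold higher number from compound 2 to compound 3 (0.57 log units; beyond the scatter) and so moves toward weaker inhibition of growth. Within the data shown here, this is the first step between compounds that differ in one place, and it shows that this position on the shared core is not indifferent to substitution, at least for bromo. No data on hand account for the step.

Going by these compounds, whether the weakening is particular to bromo or follows from any replacement of hydrogen at this carbon stays open, and fluoro, methoxy or an amine there would separate the two. Also open, on these data alone, is whether the step holds when the methyl ester of compound 2 gives way to a carboxylic acid.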